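Swapping a Phenylpiperazine for a Pentyl Chain

The compounds below may be only part of what the source reports. "The series", "measured", "known", "first", "only" and "open" are said of these compounds alone.

compound 1 `CCCCCCOc1nc(C(C)(C)C)ccc1CNC(=O)C(C)c1ccc(NS(C)(=O)=O)c(F)c1` — 2.7 nM
compound 2 `CC(C(=O)NCc1ccc(C(C)(C)C)cc1N1CCN(c2ccccc2)CC1)c1ccc(NS(C)(=O)=O)c(F)c1` — 0.8 nM
compound 3 `C[C@H](C(=O)NCc1ccc(C(C)(C)C)cc1SC1CCCCC1)c1ccc(NS(C)(=O)=O)c(F)c1` — 6 nM

In an assay on cells for antagonist activity at transient receptor potential cation channel subfamily V member 1 (Homo sapiens), read by FLIPR and calcium flux, with a stated time of 6 min (on this read-out lower numbers stand for stronger inhibition and higher numbers for weaker inhibition), compound 2 gives the lowest number of the three, and its gaps to compound 1 and to compound 3 both lie beyond the usual scatter, so compound 2 is the strongest inhibitor among the measured compounds. Compound 4 `CCCCCc1cc(C(C)(C)C)ccc1CNC(=O)C(C)c1ccc(NS(C)(=O)=O)c(F)c1` has not been measured. It differs from compound 2 in one place: pentyl in place of 4-phenylpiperazin-1-yl on an aromatic carbon. For the measured compounds named here, no measured pair shows a change of this kind, so there is no direct guide. The expected step from compound 2 to compound 4 is a 3.8-fold higher number from compound 2 to compound 4 (0.57 log units; beyond the scatter), a modest move toward weaker inhibition, kept small since compounds 1 and 3 with other groups here remain potent. Compound 4 is therefore estimated at 3 nM, within 1 nM to 10 nM.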

Compound 4, inhibition constant: 2.8 nM
For compound 4 the middle estimate is 1.1-fold (0.03 log units) above the measured one, within the range that was stated.
By their numbers in this assay, from the lowest: compound 2; then compounds 1 and 4 (each within the scatter of the next); then compound 3.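

For the compounds shown here, this is the first direct look at a single change at this position: in this assay, pentyl in place of 4-phenylpiperazin-1-yl gives a 3.5-fold higher number from compound 2 to compound 4 (0.54 log units; beyond the scatter). The group that leaves carries two rings and two hydrogen-bond acceptors and the group that enters has neither, yet the step is modest and inhibition stays strong without those rings. Nothing measured here gives a reason for this step. Still open, going by these compounds, is how a shorter chain such as propyl, a longer chain such as octyl, or a simple amine such as piperidine would behave on this aromatic carbon.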